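This account rests on a few compounds, and the source may have more. Where it says the series, first, only, none or still open, it means among the compounds named here.

Measured so far in a functional assay on MDA-MB-435 cells (Homo sapiens) for antiproliferative activity, read by sulforhodamine B assay, with a stated time of 72 h (on this read-out higher numbers stand for weaker inhibition and lower numbers for stronger inhibition), are these compounds:

Compound 1 `O=C1CS/C(=N/Nc2nncc3ccccc23)N1c1ccccc1` gives 44 nM
Compound 2 `O=S(=O)(Nc1nccs1)c1ccc(Nc2nncc3ccccc23)cc1` gives 36 nM
Compound 3 `Fc1ccc(Nc2nncc3ccccc23)cc1` gives 4 nM

Compound 3 has the lowest number of the three, at 4 nM, so it shows the strongest inhibition in this small set. Its gaps to compound 2 and to compound 1 both lie beyond the usual scatter of repeated measurements.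

The next compound is compound 4 `NS(=O)(=O)c1ccc(Nc2nncc3ccccc23)cc1`. It differs from compound 3 by having sulfamoyl in place of fluoro on an aromatic carbon, para to a large group (sulfamoyl in place of fluoro on an aromatic carbon). For the measured compounds named here, no measured pair shows this change on its own, so any forecast has to lean on indirect evidence. The closest guide is compound 2, a substituted sulfamoyl relative, at 36 nM. Going by the values given here, this suggests that compound 4 will land nearer that value than the one for compound 3, although the smaller group could behave differently.

In this assay, the expected result is a 7.5-fold higher number from compound 3 to compound 4 (0.88 log units; beyond the scatter), a move toward weaker inhibition and probably beyond the scatter. For compound 4 the estimated value is 30 nM, with an expected range from 8 nM to 120 nM.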

Compound 4, half-maximal inhibitory concentration: 18 nM
Compound 4: middle estimate off by 1.7-fold (0.22 log units), on the high side, and the stated range covers the measured number.
By their numbers in this assay, from the lowest: compound 3; then compounds 4, 2 and 1 (each within the scatter of the next, the first and the last beyond it).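

In this assay, for the compounds shown here, sulfamoyl in place of fluoro on an aromatic carbon, para to a large group, gives a 4.5-fold higher number from compound 3 to compound 4 (0.65 log units; beyond the scatter) and provides the first direct reading of a change at this place: the larger group costs some inhibition, and the step is modest. The second comparison concerns the sulfonamide nitrogen, where hydrogen in place of 1,3-thiazol-2-yl gives a 2.0-fold lower number from compound 2 to compound 4 (0.30 log units; within the scatter) and so leaves the two compounds indistinguishable on this read-out, which means that the ring on that nitrogen has no effect here that stands clear of the scatter. The data shown offer no measurement that explains either step.

From the compounds shown here alone, only fluoro and sulfamoyl can be compared at the aromatic carbon, so it remains open whether the low number of compound 3 is particular to fluoro or would also appear with chloro, methoxy or a plain hydrogen in the same place. Going by these compounds, on the sulfonamide nitrogen, only hydrogen and 1,3-thiazol-2-yl can be compared, so the outcome with a methyl group or a longer chain there is still unknown.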